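Removing One Methoxy Group from Compound 1

This account rests on a few compounds, and the source may have more. Where it says the series, first, only, none or still open, it means among the compounds named here.

Within the data shown here, compound 1 `C=CC[C@H]1C[C@]2([C@@H](C)Cc3ccc(OC)c(OC)c3)OCOC2=CC1=O` is the only compound of this pair with a numerical result: in a functional assay on M14 cells (Homo sapiens) for antiproliferative activity, with a stated time of 72 h (on this read-out higher numbers stand for weaker inhibition and lower numbers for stronger inhibition), compound 1 gives 110 nM. Compound 2 `C=CC[C@@H]1C[C@]2([C@@H](C)Cc3ccc(OC)c(OC)c3)OCOC2=CC1=O` is reported only as a limit of the assay, since compound 2 gives > 4000 nM in this assay. Among the measured compounds shown here, the single measured step, an at least 36-fold higher number from compound 1 to compound 2 (1.56 log units; beyond the scatter), rests on the fact that compounds 1 and 2 differ only in the configuration as drawn and is bounded by the limit of > 4000 nM in this assay, at which 1 of the 2 values shown sits. That step concerns configuration alone and says nothing about substituents on the aromatic ring.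

Compound 3 `C=CC[C@H]1C[C@]2([C@@H](C)Cc3ccc(OC)cc3)OCOC2=CC1=O` differs from compound 1 by hydrogen in place of methoxy on an aromatic carbon; a methoxy group leaves and a hydrogen atom takes its place, on the carbon ortho to the remaining methoxy group and meta to the large group. For the measured compounds named here, no measured step touches this kind of change, so the expectation draws only on the value of compound 1, with wide uncertainty. A modest weakening of inhibition, a 2.3-fold higher number from compound 1 to compound 3 (0.36 log units; beyond the scatter), is estimated. Compound 3 is therefore expected to give about 250 nM in this assay, within a range from 80 nM to 1500 nM.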

Compound 3, half-maximal inhibitory concentration: 20 nM
Compound 3: the middle estimate sits 13-fold (1.10 log units) above what was measured; measured number below the stated range.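

At this aromatic carbon, ortho to the remaining methoxy group and meta to the large group, replacing methoxy with a hydrogen atom gives a 5.5-fold lower number from compound 1 to compound 3 (0.74 log units; beyond the scatter) in this assay, so inhibition becomes stronger rather than weaker. The earlier pair showed only that configuration at one saturated ring carbon matters, whereas this step shows that the aromatic ring can also change the result, and that the second methoxy group of compound 1 is not required for activity in the nanomolar range. Nothing reported here explains why the smaller substituent goes with the stronger inhibition.

Going by these compounds, with only methoxy and hydrogen compared at this carbon, it remains open whether a fluorine atom, a hydroxyl group or an ethoxy group there would behave more like the hydrogen of compound 3 or the methoxy group of compound 1. Also open, on these data alone, are what happens if the remaining methoxy group of compound 3 is replaced in the same way, and whether removing the methoxy group has a similar effect in the configuration drawn in compound 2.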